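The compounds below may be only part of what the source reports. "The series", "measured", "known", "first", "only" and "open" are said of these compounds alone.

Series notes. Compound 1 `COc1cccc(OC)c1OCCNCCOc1ccccc1OCc1ccccc1C` gives 0.126 nM in an assay on CHO cells for displacement of a labelled ligand from Alpha-1D adrenergic receptor (Homo sapiens); on this read-out lower numbers stand for stronger inhibition and higher numbers for weaker inhibition; compound 2 `COc1cccc(OC)c1OCCNCCOc1ccccc1OCc1cccc(C)c1` gives 0.2 nM; compound 3 `COc1cccc(OC)c1OCCNCCOc1ccccc1OCc1ccccc1[N+](=O)[O-]` gives 0.912 nM. Compound 3 thus stands at the highest number of the three, with a 4.6-fold higher number from compound 2 to compound 3 (0.66 log units; beyond the scatter) and a 7.2-fold higher number from compound 1 to compound 3 (0.86 log units; beyond the scatter). The next compound, compound 4 `COc1cccc(OC)c1OCCNCCOc1ccccc1OCc1cccc([N+](=O)[O-])c1`, differs from compound 3 in one place: 3-nitrophenyl in place of 2-nitrophenyl on a saturated chain carbon bound to an oxygen on an aromatic ring. Going by the values given here, the only measured step of the same kind, the corresponding move of a methyl group, is a 1.6-fold higher number from compound 1 to compound 2 (0.20 log units; within the scatter), which lies within the scatter. On that precedent, the move of the nitro group is expected to leave this assay about unchanged, the expected step being a 1.1-fold higher number from compound 3 to compound 4 (0.04 log units; within the scatter). Compound 4 is therefore estimated at 1 nM, with a range from 0.35 nM to 3 nM.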

Compound 4, inhibition constant: 0.0631 nM
Estimate against measurement, compound 4: 16-fold (1.20 log units) above; the whole stated range lies above it.
By their numbers in this assay, from the lowest: compounds 4, 1 and 2 (each within the scatter of the next, the first and the last beyond it); then compound 3.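

In this assay, the placement of the nitro group matters at this position, with 3-nitrophenyl in place of 2-nitrophenyl giving a 14-fold lower number from compound 3 to compound 4 (1.16 log units; beyond the scatter), a sensitivity the methyl pair did not show. The 3-nitrophenyl group cannot be separated from 2-methylphenyl, at a 2.0-fold lower number from compound 1 to compound 4 (0.30 log units; within the scatter), but it gives a lower number than 3-methylphenyl, at a 3.2-fold lower number from compound 2 to compound 4 (0.50 log units; beyond the scatter). Nitro in place of methyl therefore has no single direction here, and its sign differs between the two placements: the same change on two cores in this assay, a 7.2-fold higher number (0.86 log units; beyond the scatter) from compound 1 to compound 3 and a 3.2-fold lower number (0.50 log units; beyond the scatter) from compound 2 to compound 4, 23-fold (1.36 log units) apart, beyond the scatter of two such steps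

The compounds shown leave open whether a nitrile or an amine on the phenyl ring would depend on placement as the nitro group does or as the methyl group does. What lies behind the nitro group's dependence on placement also remains open.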